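Furan-2-yl in place of 3-fluorophenyl on the chain

The source may hold more compounds than are shown below. What is called first, only, known or untested is meant among the compounds shown, and "the series" means these compounds.

Working notes on the series. Compound 1 `COc1ccc(C(=O)/C=C/c2cc(OC)c(OC)c(OC)c2)c2c1C=CC(C)(C)O2` gives 9700 nM in a functional assay on SK-OV-3 cells (Homo sapiens) for antiproliferative activity, read by MTT assay, with a stated time of 24 h; a higher number here means a weaker inhibitor, a lower number a stronger inhibitor. Compound 3 `COc1ccc(C(=O)/C=C/c2cccc(C(F)(F)F)c2)c2c1C=CC(C)(C)O2` gives 9330 nM in this assay. For compound 2 `COc1ccc(C(=O)/C=C/c2cccc(F)c2)c2c1C=CC(C)(C)O2` this assay reports only a limit, > 10000 nM, and among the numbers shown compound 2 stands as a limit alone. For the measured compounds named here, the single measured step, an at least 1.0-fold lower number from compound 2 to compound 3 (0.03 log units; that floor lies within the scatter), stays within the scatter and rests on the limit (the limit of > 10000 nM in this assay, at which 1 of the 3 values shown sits). Compound 4 `COc1ccc(C(=O)/C=C/c2ccco2)c2c1C=CC(C)(C)O2` differs from compound 2 by furan-2-yl in place of 3-fluorophenyl on a double-bonded chain carbon bound to a double-bonded chain carbon. Going by the values given here, no measured step covers this change; with compound 3 at 9330 nM and the step of an at least 1.0-fold lower number from compound 2 to compound 3 (0.03 log units; that floor lies within the scatter) within the scatter, no move beyond the scatter is expected in this assay. The estimated step is a number no higher from compound 2 to compound 4 (the limit leaves the size open). Compound 4 is expected near 10000 nM, between 5000 nM and 20000 nM.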

Compound 4, half-maximal inhibitory concentration: > 10000 nM
Compound 4: only a limit was reported; the forecaster's own chance of this, stated with the estimate: 50%; the middle value sits exactly at the limit.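

No step can be read from compound 2 to compound 4, since both stand only as limits in this assay: the limit of > 10000 nM in this assay, at which 2 of the 4 values shown sit.

Whether furan-2-yl in place of 3-fluorophenyl changes the number at all stays open with the compounds shown.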